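Swapping the aryl ketone group on a thiophene-based adenosine ligand

The source may report more compounds than this note shows. Statements on the series, on what has been measured and on what is new or still open speak of the compounds shown alone.

Compounds measured so far:
compound 1, `Cc1ccc(C(=O)c2c(N)sc(-c3ccccc3)c2CC(C)(C)C)cc1`, 1%
compound 2, `COc1ccc(-c2sc(N)c(C(=O)c3ccc(Cl)c(Cl)c3)c2CC(C)(C)C)cc1`, 1%

The read-out is an assay on CHO cells for displacement of a labelled ligand from adenosine receptor A1 (Homo sapiens), read by scintillation counting, tested at 10 uM; on this read-out lower numbers stand for less inhibition and higher numbers for more inhibition at the one concentration tested (going by the name of the read-out). In this assay compound 1 gives 1%, and compound 2 gives 1%. Compound 2 therefore stands level with compound 1 at the digits shown; the two values lie within the scatter of each other, so no difference between them can be claimed.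

The next compound, compound 3, has the structure `COc1ccc(-c2sc(N)c(C(=O)c3ccc(C)cc3)c2CC(C)(C)C)cc1`. It differs from compound 2 in one place: 4-methylphenyl in place of 3,4-dichlorophenyl on a carbonyl carbon. The group that enters is the same 4-methylphenyl group that compound 1 carries on a carbonyl carbon, while the rest of compound 3 matches compound 2.

Going by the values given here, no step between two measured compounds that differ in exactly this way is available, so the size of the effect is not known from data. Since compound 1 and compound 2 both show a low value in this assay, a change of this kind is not expected to move the read-out beyond the scatter. For compound 3 the estimate is 1%, with a range from 0% to 10%, which corresponds to an expected step of no change at the digits printed from compound 2 to compound 3 (within the scatter).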

Compound 3, a percentage reported as inhibition, at one concentration (the size of the read-out at that concentration, not a potency): 1%
Estimate against measurement, compound 3: no gap at the digits printed; the range from low to high includes it.
By their numbers in this assay, from the lowest: compounds 1, 2 and 3 (each within the scatter of the next).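

In this assay, putting 4-methylphenyl in place of 3,4-dichlorophenyl on a carbonyl carbon gives no change at the digits printed from compound 2 to compound 3 (within the scatter), so this position now has a measured step rather than an estimate: losing both chlorine atoms and adding one methyl group leaves the read-out unmoved. Compound 3 also gives a step at a second place, since methoxy in place of hydrogen on an aromatic carbon gives no change at the digits printed from compound 1 to compound 3 (within the scatter); neither of these two single changes lifts the read-out away from the low level shared by all three compounds. Going by these compounds alone, with every value this low, the steps show only that these particular swaps do not raise the inhibition at the one concentration tested, and nothing measured here gives an explanation for that.

The compounds shown leave open whether a different group on the carbonyl carbon, such as an aryl ring carrying an amine or a carboxylic acid, would give a read-out clear of this low level. They also leave open whether 4-methylphenyl and 3,4-dichlorophenyl would still match on a compound with a much higher starting value, where a difference would have room to appear.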